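The source may hold more compounds than are shown below. What is called first, only, known or untested is meant among the compounds shown, and "the series" means these compounds.

Measured in an ADME assay on microsomes from liver (Canis lupus familiaris) for metabolic stability, read by LC-MS, using NADPH, with a stated time of 10 min, tested at 0.1 uM; on this read-out higher numbers stand for fast clearance and lower numbers for slow clearance:
- compound 1 `COc1ccc(F)cc1N1C(=O)CSC1c1cccc(C(=O)NCCCCn2cccn2)c1`: 480 mL.min-1.g-1
- compound 2 `Cc1ccnc(N2C(=O)CSC2c2cccc(C(=O)NCCCCn3cccn3)c2)c1`: 41.8 mL.min-1.g-1
- compound 3 `O=C(NCCCCc1ccccc1)c1cccc(C2SCC(=O)N2c2cccc(-c3c[nH]nn3)c2)c1`: 226 mL.min-1.g-1

Compound 3 stands second highest of the three, below compound 1 and above compound 2. Compound 4 `O=C(NCCCCc1ccccc1)c1cccc(C2SCC(=O)N2c2ccc(C3CC3)cc2)c1` differs from compound 3 on an amide-type nitrogen in a ring: a group of 9 heavy atoms (9 carbon; one three-membered non-aromatic ring of carbon only, one six-membered aromatic ring of carbon only) in place of a group of 11 heavy atoms (8 carbon, 3 nitrogen; one five-membered aromatic ring with 3 hetero atoms, one six-membered aromatic ring of carbon only), on an amide-type nitrogen in a ring. Among the compounds with values here, only one measured step bears on that nitrogen, the large 11-fold lower number from compound 1 to compound 2 (1.06 log units; beyond the scatter), and it involves other groups, so it shows that this place can matter without sizing this change. Compound 1, with a ring of carbon only there, has the highest value, so a modest rise is expected. The estimated step is a 1.7-fold higher number from compound 3 to compound 4 (0.23 log units; within the scatter). Compound 4 is expected at 380 mL.min-1.g-1, within an estimated range of 170 mL.min-1.g-1 to 850 mL.min-1.g-1.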

Compound 4, intrinsic clearance in microsomes: 1080 mL.min-1.g-1
For compound 4 the middle estimate is 2.8-fold (0.45 log units) below the measured one, and the stated range ends below it.
By their numbers in this assay, from the lowest: compound 2; then compound 3; then compound 1; then compound 4.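

In this assay, replacing the group on the amide-type nitrogen gives a 4.8-fold higher number from compound 3 to compound 4 (0.68 log units; beyond the scatter), so this nitrogen also matters with the different amide chain shared by compound 3 and compound 4. Here the entering 4-cyclopropylphenyl has 0 hydrogen-bond donors and 0 acceptors, whereas the leaving group has 1 donor and 2 acceptors. No available evidence explains the rise. The compounds shown leave open whether the step follows the loss of the five-membered aromatic ring or the gain of the cyclopropyl ring. On these data alone, how a plain phenyl, or a phenyl bearing a carboxylic acid, would compare also remains open.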